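Chloro to methyl swap on two differently joined cores

This account rests on a few compounds, and the source may have more. Where it says the series, first, only, none or still open, it means among the compounds named here.

Compound 1 `COc1ccc2c(c1)[n+]([O-])c(C#N)c(-c1ccc(Cl)cc1)[n+]2[O-]` gives 2.09 in a physicochemical assay for lipophilicity, measured as octanol-water partition; on this read-out lower numbers stand for lower lipophilicity and higher numbers for higher lipophilicity. Compound 2 `COc1ccc2c(c1)[n+]([O-])c(C#N)c(-c1ccc(C)cc1)[n+]2[O-]` carries methyl in place of chloro on an aromatic carbon, and in this assay compound 2 gives 1.83; the measured step is a number 0.26 log units lower from compound 1 to compound 2 (within the scatter). Compound 3 `COc1ccc(-c2c(C#N)[n+]([O-])c3cc(Cl)ccc3[n+]2[O-])cc1` has the same atoms as compound 1 joined differently; the difference between the two cores is not broken down here. In this assay compound 3 gives 2.09, level with compound 1 at the digits shown and within the scatter. Compound 4 `COc1ccc(-c2c(C#N)[n+]([O-])c3cc(C)ccc3[n+]2[O-])cc1` carries methyl in place of chloro on an aromatic carbon. This is the same kind of change as that to compound 2, but the place differs: there the aromatic carbon was para to a large group; here the ring is part of a fused or bridged system of two rings, meta to a fused ring and para to a fused ring. Resting on the measured step of a number 0.26 log units lower from compound 1 to compound 2 (within the scatter), a step of like size is expected, namely a number 0.26 log units lower from compound 3 to compound 4 (within the scatter). Compound 4 is accordingly estimated at 1.83.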

Compound 4, partition coefficient: 1.83
Beside the measured number, compound 4's estimate shows no gap at the digits printed, within the range that was stated.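

In this assay the swap of chloro for methyl gives a number 0.26 log units lower from compound 3 to compound 4 (within the scatter) on the second core and a number 0.26 log units lower from compound 1 to compound 2 (within the scatter) on the first core, so the two readings agree across the differently joined cores. Both steps lie within the scatter, so this pair supports only a matching result on these two cores and does not establish a real shift from the swap on either one. No measurement shown bears on why the two steps match.

The compounds shown leave open whether a step carries across these cores for other groups in the same place, such as an amine, a carboxylic acid or a longer chain. Replacement of the nitrile or the methoxy group, both common to all four compounds, also remains open.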